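Replacing the Furan on the Amine Side Chain of Compound 1

This account rests on a few compounds, and the source may have more. Where it says the series, first, only, none or still open, it means among the compounds named here.

Compound 1 `Fc1ccc(-c2ccc3c(NCCCNCc4ccco4)ccnc3c2)cc1` was tested in an ADME assay on HepG2 cells (Homo sapiens) for cytotoxicity, read by luminescence, CellTiter-Glo and ATP content, with a stated time of 72 h (a lower number here means that less compound is needed, a higher number that more compound is needed for the effect), where compound 1 gives 7760 nM. Two other compounds share its core. Compound 2 `Fc1ccc(Cc2ccc3c(NCCCNCc4ccco4)ccnc3c2)c(Cl)c1` gives 5730 nM, and compound 3 `Cc1cc(C)cc(Cc2ccc3c(NCCCNCc4ccco4)ccnc3c2)c1` gives 6270 nM. Of the three numbers, compound 1 has the highest, but the steps of a 1.4-fold lower number from compound 1 to compound 2 (0.13 log units; within the scatter) and a 1.2-fold lower number from compound 1 to compound 3 (0.09 log units; within the scatter) both stay within the scatter, as does a 1.1-fold higher number from compound 2 to compound 3 (0.04 log units; within the scatter), so the three compounds cannot be ordered.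

Compound 4 `COc1cccc(CNCCCNc2ccnc3cc(-c4ccc(F)cc4)ccc23)c1O` has not been measured. It differs from compound 1 by 2-hydroxy-3-methoxyphenyl in place of furan-2-yl on a saturated chain carbon bound to an amine nitrogen. Within the data shown here, none of the measured steps touches this part of the molecule; all of them alter the aromatic group on the other side of the core, and each of those changes stayed within the scatter. There is therefore no measured step that bears directly on the change to compound 4, and no reason from the data to expect a step beyond the scatter in this assay in either direction. The estimated step is a 1.0-fold higher number from compound 1 to compound 4 (0.00 log units; within the scatter). Compound 4 is expected to give about 7800 nM, with a range from 3500 nM to 17000 nM.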

Compound 4, half-maximal effective concentration: 6840 nM
Compound 4: the middle estimate sits 1.1-fold (0.06 log units) above what was measured; low and high end bracket the measured number.
By their numbers in this assay, from the lowest: compounds 2, 3, 4 and 1 (each within the scatter of the next).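

Among these compounds, this is the first measured change on the amine side chain, and in this assay putting 2-hydroxy-3-methoxyphenyl in place of furan-2-yl on a saturated chain carbon bound to an amine nitrogen gives a 1.1-fold lower number from compound 1 to compound 4 (0.05 log units; within the scatter) and stays within the scatter. The exchange is a large one in structural terms, from 5 heavy atoms to 9, from a five-membered aromatic ring with 1 hetero atom to a six-membered aromatic ring of carbon only, and from 0 hydrogen-bond donors to 1, yet it leaves the number indistinguishable from that of compound 1. No available evidence accounts for this result.

Going by these compounds, the hydroxy and methoxy groups enter together, so what each does alone remains open. Also open, on these data alone, is whether a carboxylic acid, a morpholine or a longer chain at this place would give a step beyond the scatter.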